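Thiophene to methoxypyridine: what clearance to expect

The compounds below may be only part of what the source reports. "The series", "measured", "known", "first", "only" and "open" are said of these compounds alone.

In an ADME assay (liver) for metabolic stability, with Liver microsome (Rattus norvegicus) as the target, using microsomes and NADPH, with a stated time of 30 min, tested at 1 uM; a higher number here means faster removal of the compound, a lower number slower removal:
Compound 1 `Nc1ccc(S(=O)(=O)N2CCN(c3ncc(C(O)(C(F)(F)F)C(F)(F)F)cc3C#CCO)CC2)cn1` gives 65 mL.min-1.g-1
Compound 2 `Cc1csc(-c2cc(C(O)(C(F)(F)F)C(F)(F)F)cnc2N2CCN(S(=O)(=O)c3ccc(N)nc3)CC2)c1` gives 399 mL.min-1.g-1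
Compound 3 `Nc1ccc(S(=O)(=O)N2CCN(c3ncc(C(O)(C(F)(F)F)C(F)(F)F)cc3-c3cncc(F)c3)CC2)cn1` gives 19 mL.min-1.g-1

Compound 2 stands highest of the three, with its nearest neighbour compound 1 and compound 3 far below it. Compound 4 `COc1cncc(-c2cc(C(O)(C(F)(F)F)C(F)(F)F)cnc2N2CCN(S(=O)(=O)c3ccc(N)nc3)CC2)c1` differs from compound 2 in one place: 5-methoxypyridin-3-yl in place of 4-methylthiophen-2-yl on an aromatic carbon. The step that bears most directly on this is a 21-fold lower number from compound 2 to compound 3 (1.32 log units; beyond the scatter), where a six-membered pyridine also took the place of the thiophene. The steps of a 6.1-fold higher number from compound 1 to compound 2 (0.79 log units; beyond the scatter) and a 3.4-fold lower number from compound 1 to compound 3 (0.53 log units; beyond the scatter) point the same way, the thiophene sitting at the fast end. A large drop is therefore expected in this assay for compound 4, roughly a 10-fold lower number from compound 2 to compound 4 (1.00 log units; beyond the scatter). Compound 4 is estimated at 40 mL.min-1.g-1, with a likely range from 12 mL.min-1.g-1 to 130 mL.min-1.g-1.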

Compound 4, intrinsic clearance in microsomes: 58 mL.min-1.g-1
Estimate against measurement, compound 4: 1.5-fold (0.16 log units) below; the range from low to high includes it.
By their numbers in this assay, from the lowest: compound 3; then compounds 4 and 1 (each within the scatter of the next); then compound 2.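

In this assay the fall seen with the fluoropyridine is repeated by a second six-membered ring at this aromatic carbon, with a 6.9-fold lower number from compound 2 to compound 4 (0.84 log units; beyond the scatter) on replacing the 4-methylthiophen-2-yl group. The substituent on that pyridine also matters: methoxy in place of fluoro gives a 3.1-fold higher number from compound 3 to compound 4 (0.48 log units; beyond the scatter) in this read-out. With a 1.1-fold lower number from compound 1 to compound 4 (0.05 log units; within the scatter) the 5-methoxypyridin-3-yl and 3-hydroxyprop-1-yn-1-yl groups cannot be told apart here. Nothing measured here explains these steps. On these data alone, whether chloro or ethoxy on the pyridine would fall nearer fluoro or methoxy stays open.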